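Two weak pyridine-free esters and a basic side chain

A few compounds are considered here, and "the series" means these few. Any claim that something is new, unique, unknown or untested is made for them only; others in the source may bear on it.

The series opens with compound 1, `CCOC(=O)c1cccc(-c2ccc(OCC)cc2)n1`, which in an assay on COS-7 cells for inhibition of patatin-like phospholipase domain-containing protein 2 (Mus musculus) (a higher number here means a weaker inhibitor, a lower number a stronger inhibitor), gives 60000 nM. Compound 2, `CCOC(=O)c1cccc(-c2ccc(O)cc2)c1`, gives 100000 nM in this assay. Compound 2 carries the higher of the two numbers, but the gap to compound 1 lies within the scatter, so the two cannot be told apart. Compound 3, `CCOC(=O)c1cccc(-c2ccc(C(C)N(C)C)cc2)c1`, has not yet been measured. It differs from compound 2 in one place: 1-(dimethylamino)ethyl in place of hydroxy on an aromatic carbon. Going by the values given here, no step between measured compounds shows what such a change does here, so the expectation for compound 3 rests only on the weak numbers of compound 1 and compound 2. The step from compound 2 to compound 3 is expected to be small, a 2.0-fold lower number from compound 2 to compound 3 (0.30 log units; within the scatter), with no direction favoured beyond the scatter. Compound 3 is therefore estimated at 50000 nM, within a range of 15000 nM to 150000 nM.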

Compound 3, half-maximal inhibitory concentration: 200000 nM
Compound 3: middle estimate off by 4.0-fold (0.60 log units), on the low side; measured number above the stated range.
By their numbers in this assay, from the lowest: compounds 1, 2 and 3 (each within the scatter of the next, the first and the last beyond it).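

In this assay, the position on an aromatic carbon para to a large group now has its first readable step, a 2.0-fold higher number from compound 2 to compound 3 (0.30 log units; within the scatter), for 1-(dimethylamino)ethyl in place of hydroxy. Here the larger group, which carries no hydrogen-bond donor, brings no gain that can be told from the scatter, so neither group stands apart from the other at this position. No measurement shown gives a reason for this step.

The compounds shown leave open whether any group at this position can move the number beyond the scatter of compound 2, for example a primary amine, a carboxylic acid or a longer ether chain. They also leave open what a carboxylic acid in place of the ethyl ester would give on the shared core.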